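The source may hold more compounds than are shown below. What is called first, only, known or untested is meant among the compounds shown, and "the series" means these compounds.

In a functional assay on MDA-MB-231 cells (Homo sapiens) for antiproliferative activity, read by MTT assay, with a stated time of 24 h (on this read-out lower numbers stand for stronger inhibition and higher numbers for weaker inhibition), compound 1 `O=C(O)CC(NS(=O)(=O)c1ccccc1)c1ccccc1` gives only a limit (> 100000 nM). Compound 2 `CC(C)(C)c1ccc(S(=O)(=O)NC(CC(=O)O)c2ccccc2)cc1` likewise gives only a limit (> 100000 nM). Among the measured compounds shown here, compound 3 `O=C(O)CC(NS(=O)(=O)c1ccc(F)cc1)c1ccccc1` holds the only real number of the three (88400 nM) so it is the single firm reference point so far.

The next structure is compound 4 `N#Cc1ccc(S(=O)(=O)NC(CC(=O)O)c2ccccc2)cc1` with cyano in place of fluoro on an aromatic carbon, para to a large group (cyano in place of fluoro on an aromatic carbon). The measured steps at this same place are small or cannot be read. Fluoro in place of hydrogen gives (an at least 1.1-fold lower number from compound 1 to compound 3 (0.05 log units; that floor lies within the scatter)) and fluoro in place of tert-butyl gives (an at least 1.1-fold lower number from compound 2 to compound 3 (0.05 log units; that floor lies within the scatter)) while tert-butyl in place of hydrogen gives (a step that the two limits leave unreadable from compound 1 to compound 2). For the measured compounds named here, none of these shows a change beyond the scatter, and no cyano compound has been measured yet. On that basis, no step beyond the scatter is expected in this assay for this swap. The expected change is small by estimate (a 1.0-fold higher number from compound 3 to compound 4 (0.01 log units; within the scatter)). Compound 4 is estimated at 90000 nM with an expected range from 45000 nM to 180000 nM for a measured number.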

Compound 4, half-maximal inhibitory concentration: 48700 nM
For compound 4 the middle estimate is 1.8-fold (0.27 log units) above the measured one; the measured number falls inside the stated range.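

Among the compounds shown here, with cyano on this aromatic carbon, this assay shows the first steps at this position that lie beyond the scatter: an at least 2.0-fold lower number from compound 1 to compound 4 (0.31 log units; beyond the scatter) and also an at least 2.0-fold lower number from compound 2 to compound 4 (0.31 log units; beyond the scatter). Both are only floors, because compound 1 and compound 2 each give a limit rather than a number: the limit of > 100000 nM in this assay, at which 2 of the 4 values shown sit. Against the only firm earlier value, the swap of cyano for fluoro gives a 1.8-fold lower number from compound 3 to compound 4 (0.26 log units; within the scatter), so no real gain over fluoro can be claimed.

The compounds shown leave open whether another group at this position, such as an amine or a trifluoromethyl group, would move the number further than cyano does. They also do not show why cyano and fluoro give readable numbers while hydrogen and tert-butyl give only limits.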